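This account rests on a few compounds, and the source may have more. Where it says the series, first, only, none or still open, it means among the compounds named here.

Measured in a functional assay on HL-60 cells (Homo sapiens) for antiproliferative activity, read by MTT assay, with a stated time of 48 h; on this read-out higher numbers stand for weaker inhibition and lower numbers for stronger inhibition:
- compound 1 `CCN(CC)CCn1c(N)c(-c2nc3ccccc3[nH]2)c2nc(C#N)c(C#N)nc21`: 1880 nM
- compound 2 `N#Cc1nc2c(-c3nc4ccccc4[nH]3)c(N)n(CCO)c2nc1C#N`: > 50000 nM (a limit)
- compound 3 `CCN(CC)CCCn1c(N)c(-c2nc3ccccc3[nH]2)c2nc(C#N)c(C#N)nc21`: > 730 nM (a limit)

Compound 3 has no number, only the limit > 730 nM.

Compound 4 `CN(C)CCCCCn1c(N)c(-c2nc3ccccc3[nH]2)c2nc(C#N)c(C#N)nc21` has the same atoms as compound 3, joined differently: 2-(dimethylamino)ethyl in place of diethylamino on a saturated chain carbon, three bonds along the chain from an aromatic nitrogen.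

Among the compounds with values here, two measured steps bear on this: an at least 26-fold higher number from compound 1 to compound 2 (1.42 log units; beyond the scatter), which is large, and a step that the limit leaves unreadable from compound 1 to compound 3. Neither measures this change directly. Compound 4 keeps an amino end group, as does compound 1 at 1880 nM, so a value near that one is expected. The expected step is a step that the limit leaves unreadable from compound 3 to compound 4, with its direction uncertain since it starts from a limit. Compound 4 is estimated at 1500 nM, with an expected range of 350 nM to 7000 nM.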

Compound 4, half-maximal inhibitory concentration: 3420 nM
Beside the measured number, compound 4's estimate is 2.3-fold (0.36 log units) below it; the range from low to high includes it.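

In this assay the 5-(dimethylamino)pentyl chain of compound 4 is not separated from the 2-(diethylamino)ethyl chain of compound 1, with a 1.8-fold higher number from compound 1 to compound 4 (0.26 log units; within the scatter) between them. A dimethylamino end group also stands well apart from hydroxy, with an at least 14-fold lower number from compound 2 to compound 4 (1.16 log units; beyond the scatter) on this read-out. The steps involving compound 3 cannot be read, since compound 3 has only a limit: the limit of > 730 nM in this assay, at which 1 of the 4 values shown sits.

Going by these compounds, whether 3-(diethylamino)propyl and 5-(dimethylamino)pentyl differ therefore remains open. So does the outcome for a piperidine or morpholine at the chain end, or for a carboxylic acid there.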